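Swapping a sec-butyl for carbamoylmethyl on an ester series

The source may report more compounds than this note shows. Statements on the series, on what has been measured and on what is new or still open speak of the compounds shown alone.

Of the compounds shown here, three sharing a common core have been tested so far in a functional assay on the whole organism (Tail, strain ICR) with Mus musculus as the target, in the tail flick test, with a stated time of 30 min, at a dose of 25 umol/kg by the oral route; a higher number here means a stronger effect of the compound at the dose given, a lower number a weaker effect. Compound 1 `O=C(CN(c1nc(Cl)nc2[nH]cnc12)C1CC1)NCC(=O)OCc1ccccc1` gives 18.7% in this assay. Compound 2 `CC[C@H](C)[C@H](NC(=O)CN(c1ncnc2c1ncn2C1CCCCO1)C1CC1)C(=O)OCc1ccccc1` gives 25.6% in this assay, and compound 3 `O=C(O)CC[C@H](NC(=O)CN(c1nc(Cl)nc2[nH]cnc12)C1CC1)C(=O)O` gives 26.8% in this assay. The number for compound 2 differs from that of compound 3 and from that of compound 1 by amounts that stay within the usual scatter of repeated measurements, so none of the three can be told apart from the others on these figures.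

Compound 4 `NC(=O)C[C@H](NC(=O)CN(c1ncnc2c1ncn2C1CCCCO1)C1CC1)C(=O)OCc1ccccc1` has not yet been measured in this assay. Compared with compound 2 it differs in one place: carbamoylmethyl in place of sec-butyl on a saturated chain carbon bound to an amide-type nitrogen and a carbonyl carbon. Going by the values given here, no pair of measured compounds differing in exactly one place is available, so the size of this kind of step has not been seen directly. With the three measured numbers lying so close together, the step from compound 2 to compound 4 in this assay is expected to be small, with no direction beyond the scatter, and is estimated as a number 1.6 percentage points lower from compound 2 to compound 4 (within the scatter). Compound 4 is therefore expected to give about 24% in this assay, within a range from 10% to 38%.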

Compound 4, a percentage reported as activity, at one dose (the size of the read-out at that dose, not a potency): 34.5%
For compound 4 the middle estimate is 10.5 percentage points below the measured one; the range from low to high includes it.
By their numbers in this assay, from the lowest: compounds 1, 2, 3 and 4 (each within the scatter of the next, the first and the last beyond it).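

Going by these compounds alone, this is the first change in the set that can be read at a single place: in this assay, carbamoylmethyl in place of sec-butyl on a saturated chain carbon bound to an amide-type nitrogen and a carbonyl carbon gives a number 8.9 percentage points higher from compound 2 to compound 4 (within the scatter), a step that cannot be told from repeated measurement. At this place, then, a group without hydrogen-bond donors or acceptors can give way to one with a hydrogen-bond donor and a hydrogen-bond acceptor and the same count of heavy atoms, and the read-out does not move beyond the scatter. No measurement of any property of these compounds bears on this step.

One pair cannot show whether the same step would stay within the scatter on the core of compound 1, where this carbon carries neither group. It also leaves open how a carboxylic acid, an amine or a longer chain at this place would read in this assay, and whether any of them would move the number beyond the scatter from that of compound 2.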